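The source may hold more compounds than are shown below. What is called first, only, known or untested is meant among the compounds shown, and "the series" means these compounds.

Measured so far in the series:
compound 1, `Oc1ccc(CNc2cc(Br)cc3[nH]ncc23)c(F)c1` — "not active" (no number reported)
compound 2, `Oc1ccc(CNc2cc(Br)cc3[nH]ncc23)cc1F` — 26%
compound 3, `Cc1cc(CNc2cc(Br)cc3[nH]ncc23)ccc1O` — 30%

In an assay for inhibition of Tryptophan 2,3-dioxygenase (Homo sapiens), with a stated time of 1 h, tested at 10 uM (a higher number here means more inhibition at the concentration tested (going by the name of the read-out), a lower number less inhibition), compound 2 gives 26% and compound 3 gives 30%; the step of a number 4 percentage points higher from compound 2 to compound 3 (within the scatter) comes from methyl in place of fluoro on an aromatic carbon. Compound 1 is reported in this assay as "not active" (no number reported). The difference between the cores of compound 1 and compound 2 is not broken down here.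

Compound 4, `Cc1cc(O)ccc1CNc1cc(Br)cc2[nH]ncc12`, differs from compound 1 by methyl in place of fluoro on an aromatic carbon. This is the same kind of change as that from compound 2 to compound 3, but not the same: there the place is ortho to a hydroxy group and meta to a large group, here it is ortho to a large group and meta to a hydroxy group. Because a number 4 percentage points higher from compound 2 to compound 3 (within the scatter) lies within the scatter, the step from compound 1 to compound 4 in this assay is expected to be small as well. Compound 4 is therefore estimated at 10% in this assay, with an expected range from 0% to 25%.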

Compound 4, a percentage reported as inhibition, at one concentration (the size of the read-out at that concentration, not a potency): 19%
Estimate against measurement, compound 4: 9 percentage points below, and the stated range covers the measured number.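

In this assay compound 1 carries no number, so no new step can be read between compound 1 and compound 4. The compounds shown leave open how methyl and fluoro compare at this place, and no measured evidence bears on the result.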